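The source may hold more compounds than are shown below. What is called first, only, known or untested is meant among the compounds shown, and "the series" means these compounds.

Compound 3 `Nc1ncnc2c1c(Oc1cc(C(F)(F)F)ccn1)nn2[C@@H]1CC[C@H](N)C1` shares its core with two other compounds in this set. In an ADME assay on microsomes from liver (Homo sapiens) for metabolic stability, read by LC-MS, using NADPH, with a stated time of 10 min, tested at 10 uM (on this read-out lower numbers stand for a shorter-lived compound and higher numbers for a longer-lived compound), compound 3 gives only a limit, > 2.41 h, rather than a number. Compound 2 `Nc1ncnc2c1c(Oc1cc(C(F)(F)F)ccn1)nn2C1CC1` likewise reaches a limit in this assay, > 2.41 h. Compound 1 `Nc1ncnc2c1c(Oc1cc(C(F)(F)F)ccn1)nn2C1CCC1` gives a plain number in this assay, 1.02 h. The step from compound 1 is an at least 2.3-fold higher number from compound 1 to compound 3 (0.37 log units; beyond the scatter), and the parallel change gives an at least 2.3-fold higher number from compound 1 to compound 2 (0.37 log units; beyond the scatter). Between the two limit compounds the step is a step that the two limits leave unreadable from compound 2 to compound 3, because the limit of > 2.41 h in this assay, at which 2 of the 3 values shown sit, caps both values. So compound 3 stands at the top of what this assay can report, with compound 2 beside it and compound 1 below.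

Compound 4 `Nc1ncnc2c1c(Oc1cc(C(F)(F)F)ccn1)nn2[C@H]1CC[C@H](CO)CC1` differs from compound 3 only at the aromatic nitrogen: 4-(hydroxymethyl)cyclohexyl in place of 3-aminocyclopentyl on an aromatic nitrogen. Going by the values given here, no measured step covers this kind of swap; the only steps that bear on it show that changing the group on this nitrogen can move the half-life at least modestly, and that two of three neighbours sit at the limit. The expectation for compound 4 is therefore a long half-life, with the step of an at least 1.2-fold lower number from compound 3 to compound 4 (0.10 log units; that floor lies within the scatter) estimated to be small, and a value around 1.9 h, between 0.8 h and 4 h.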

Compound 4, half-life: > 2.41 h
Compound 4: only a limit was reported; the forecaster's own chance of this, stated with the estimate: 40%; middle value at least 1.2-fold (0.10 log units) away from the limit.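

Compound 4 shows that this aromatic nitrogen can carry a six-membered ring, 4-(hydroxymethyl)cyclohexyl, without the half-life dropping back to that of the cyclobutyl compound: the result is an at least 2.3-fold higher number from compound 1 to compound 4 (0.37 log units; beyond the scatter). Groups with three-, five- and six-membered rings now all reach the reporting limit in this assay, so ring size gives no simple order here, and compound 1, with its four-membered ring, is the one that goes against a plain rule that every group on this nitrogen reaches it. The steps from compound 2 and from compound 3 to compound 4 cannot be read: the limit of > 2.41 h in this assay, at which 3 of the 4 values shown sit.

As far as these compounds go, how far apart compound 2, compound 3 and compound 4 truly lie stays open. So does whether a plain cyclohexyl, a carboxylic acid or a longer open chain on this nitrogen would also reach the limit.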